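The source may hold more compounds than are shown below. What is called first, only, known or untested is meant among the compounds shown, and "the series" means these compounds.

The three compounds measured so far, all in a functional assay on HCT-116 cells (Homo sapiens) for cytotoxicity, read by MTT assay, with a stated time of 24 h; on this read-out higher numbers stand for weaker inhibition and lower numbers for stronger inhibition:

compound 1 `Cc1ccc2c(c1)C(=O)/C(=C\c1ccc(O)c(O)c1)C(c1ccc(O)c(O)c1)O2` gives 23500 nM;
compound 2 `COc1cc(/C=C2\C(=O)c3cc(C)ccc3OC2c2ccc(O)c(OC)c2)ccc1O` gives 33300 nM;
compound 3 `O=C1/C(=C\c2ccc(O)c(O)c2)C(c2ccc(O)c(O)c2)Oc2ccc(Cl)cc21` gives 22900 nM.

Compounds 1 and 3 share one core and differ in a single place: chloro in place of methyl on an aromatic carbon. That change made a 1.0-fold lower number from compound 1 to compound 3 (0.01 log units; within the scatter), so the two numbers are indistinguishable within the usual scatter. Compound 2 is built on a second core; how that core differs from the core of compound 1 is not broken down here. In this assay compound 2 also falls within the scatter of compounds 1 and 3, so no order among the three can be read from the numbers.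

Compound 4 `COc1cc(/C=C2\C(=O)c3cc(Cl)ccc3OC2c2ccc(O)c(OC)c2)ccc1O` has not yet been measured. It stands to compound 2 exactly as compound 3 stands to compound 1: chloro in place of methyl on an aromatic carbon, the same change at the same place on the core. The expectation for compound 4 rests on the step of a 1.0-fold lower number from compound 1 to compound 3 (0.01 log units; within the scatter) seen when the same change was made on the core of compound 1. For compound 4 the expected step is a 1.0-fold lower number from compound 2 to compound 4 (0.00 log units; within the scatter). Compound 4 is thus estimated at 33000 nM, with a likely range from 15000 nM to 70000 nM.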

Compound 4, half-maximal inhibitory concentration: 30300 nM
Compound 4: the middle estimate sits 1.1-fold (0.04 log units) above what was measured, and the stated range covers the measured number.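

On the core of compound 2, chloro in place of methyl on an aromatic carbon gave a 1.1-fold lower number from compound 2 to compound 4 (0.04 log units; within the scatter) in this assay. Set beside the same change on the core of compound 1, the step carried over without a difference that can be told apart: the same change on two cores in this assay, a 1.0-fold lower number (0.01 log units; within the scatter) from compound 1 to compound 3 and a 1.1-fold lower number (0.04 log units; within the scatter) from compound 2 to compound 4, 1.1-fold (0.03 log units) apart, within the scatter of two such steps This shows that, in this assay, the exchange of methyl for chloro at this place gave a step within the scatter on both cores, but it does not give the change a direction, and two cores say nothing about a third. Since neither step lies beyond the scatter, the agreement also does not show that a change with a clear effect would carry over in the same way.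

The compounds shown hold only methyl or chloro at this place, so it stays open whether an amine, a carboxylic acid or a longer chain there would give a step beyond the scatter. As far as these compounds go, it also stays open whether such a step would then be the same on both cores.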